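Methyl on the Amine Nitrogen: Expecting a Small Step

The source may hold more compounds than are shown below. What is called first, only, known or untested is meant among the compounds shown, and "the series" means these compounds.

Of the compounds shown here, two have been tested so far in a functional assay on NCI-H460 cells (Homo sapiens) for antiproliferative activity, read by sulforhodamine B assay, with a stated time of 72 h; on this read-out lower numbers stand for stronger inhibition and higher numbers for weaker inhibition. Compound 1 `CN(CCNCc1cn(Cc2ccccc2)nn1)CCNc1ccnc2cc(Cl)ccc12` gives 32000 nM. Compound 2 `Clc1ccc2c(NCCNCc3cn(-c4ccnc5cc(Cl)ccc45)nn3)ccnc2c1` gives 21000 nM. Compound 2 carries the lower of the two numbers, yet its gap to compound 1 lies within the usual scatter of repeated measurements, so the two cannot be told apart with confidence.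

Compound 3 `CN(CCNc1ccnc2cc(Cl)ccc12)Cc1cn(-c2ccnc3cc(Cl)ccc23)nn1` has not been measured. It differs from compound 2 in one place: methyl in place of hydrogen on an amine nitrogen. Everything else in the structure stays the same.

Within the data shown here, no pair of measured compounds in this set differs in a single place, so there is no direct guide to the size of such a change. Since compound 1 at 32000 nM and compound 2 at 21000 nM sit so close together in this assay, the methyl is expected to shift the value in neither direction beyond the scatter. The step of a 1.1-fold lower number from compound 2 to compound 3 (0.02 log units; within the scatter) is therefore expected to be small. For compound 3 the estimated value is 20000 nM, with a range from 7000 nM to 60000 nM.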

Compound 3, half-maximal inhibitory concentration: 29000 nM
Beside the measured number, compound 3's estimate is 1.5-fold (0.16 log units) below it; the range from low to high includes it.
By their numbers in this assay, from the lowest: compounds 2, 3 and 1 (each within the scatter of the next).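

Among these compounds, this is the first pair in the set that differs in one place, so the size of this change can now be read directly: in this assay, methyl in place of hydrogen on an amine nitrogen gives a 1.4-fold higher number from compound 2 to compound 3 (0.14 log units; within the scatter). At this position, a group of one carbon with no hydrogen-bond donors or acceptors therefore makes no difference that can be told apart from the usual scatter, and compound 2 and compound 3 cannot be separated on this read-out. No measurement at hand says why this nitrogen can carry the methyl with so little visible effect.

As far as these compounds go, whether a larger group on this nitrogen, such as an ethyl or an acetyl, would move the number beyond the scatter stays open. From the compounds shown here alone, it is also open whether the methyl would show the same small step in a compound with a longer chain.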